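Compound 3: a new phenyl group on a shared core

A few compounds are considered here, and "the series" means these few. Any claim that something is new, unique, unknown or untested is made for them only; others in the source may bear on it.

Among the measured compounds shown here, only two compounds have been measured in a physicochemical assay for solubility, in phosphate buffer, measured as kinetic solubility, at pH 7.4 (a lower number here means a less soluble compound, a higher number a more soluble compound), and neither gave an exact number. Compound 1 `Cc1oc(-c2c(Cl)cccc2Br)nc1CN1CCC(C(=O)NCCCN2C[C@H](C)C[C@H](C)C2)CC1` gives > 83 ug/mL, which is a limit of the assay. As far as these compounds go, compound 2 `Cc1ccc(-c2nc(CN3CCC(C(=O)NCCCN4C[C@H](C)C[C@H](C)C4)CC3)c(C)o2)cc1C` gives > 71 ug/mL, which is also a limit, so its exact standing remains unknown. Compound 3 `COc1cccc(OC)c1-c1nc(CN2CCC(C(=O)NCCCN3C[C@H](C)C[C@H](C)C3)CC2)c(C)o1` keeps the rest of compound 2 and differs at one place: 2,6-dimethoxyphenyl in place of 3,4-dimethylphenyl on an aromatic carbon. For the measured compounds named here, the only measured step at this place is a step that the two limits leave unreadable from compound 1 to compound 2. That step gives no size to carry forward, but neither of the two phenyl groups tried there produced a reading below a limit. On this thin evidence, no change beyond the usual scatter is expected, and the estimated step is a step that the limit leaves unreadable from compound 2 to compound 3. In this assay compound 3 is expected at 76 ug/mL, with an estimated range of 45 ug/mL to 100 ug/mL. The result may again be reported only as a limit.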

Compound 3, solubility: > 76 ug/mL
Compound 3 ended at the assay's limit; the forecaster's own chance of this, stated with the estimate: 80%; the middle value lies on the limit itself.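

In this assay compound 3 gives > 76 ug/mL, which is a limit of the assay. Among the compounds shown here, compound 1, compound 2 and compound 3 all end at limits, and no step among them can be read. As far as these compounds go, the exact solubility of each compound, and whether these three phenyl groups differ at all, stay open.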